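A hydroxy group on the phenyl of compound 2

The source may hold more compounds than are shown below. What is called first, only, known or untested is meant among the compounds shown, and "the series" means these compounds.

Measured in a functional assay on HT-29 cells (Homo sapiens) for antiproliferative activity, read by MTT assay, with a stated time of 48 h; on this read-out lower numbers stand for stronger inhibition of growth and higher numbers for weaker inhibition of growth
compound 1 `CCOC(=O)N1N=C(c2ccccc2)CC1c1cc(OC)c(OC)c(OC)c1` gives 8920 nM
compound 2 `CCCOC(=O)N1N=C(c2ccccc2)CC1c1cc(OC)c(OC)c(OC)c1` gives > 10000 nM as a limit
compound 3 `COc1cc(C2CC(c3ccccc3)=NN2C(=O)OCc2ccccc2)cc(OC)c1OC` gives > 10000 nM as a limit

On these numbers compound 2 stands at the limit of > 10000 nM in this assay, at which 2 of the 3 values shown sit, and has no exact value. The change to compound 4 `CCCOC(=O)N1N=C(c2cccc(O)c2)CC1c1cc(OC)c(OC)c(OC)c1` is hydroxy in place of hydrogen on an aromatic carbon and reads phenyl to 3-hydroxyphenyl. Going by the values given here, no measured step touches that ring. All three change the saturated chain instead, showing an at least 1.1-fold higher number from compound 1 to compound 2 (0.04 log units; that floor lies within the scatter) and an at least 1.1-fold higher number from compound 1 to compound 3 (0.04 log units; that floor lies within the scatter) and also a step that the two limits leave unreadable from compound 2 to compound 3 here. They give no size for this change, so only a small, weakly supported step is expected in this assay namely an at least 1.4-fold lower number from compound 2 to compound 4 (0.15 log units; that floor lies within the scatter) as estimated. For compound 4 the estimate is 7000 nM with an expected range of 1500 nM to 20000 nM overall.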

Compound 4, concentration for 50% growth inhibition: 15200 nM
Compound 4: middle estimate off by 2.2-fold (0.34 log units), on the low side; the measured number falls inside the stated range.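

Going by these compounds alone, no step from compound 2 to compound 4 can be read, because compound 2 carries only a limit: the limit of > 10000 nM in this assay, at which 2 of the 4 values shown sit. The compounds shown leave open how much phenyl to 3-hydroxyphenyl changes growth inhibition.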